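The source may hold more compounds than are shown below. What is called first, only, known or untested is meant among the compounds shown, and "the series" means these compounds.

Of the compounds shown here, two have been measured so far. Compound 1 `COC(=O)/C=C/c1cccc(N(Cc2ccc(/C=C/c3cccc(C(F)(F)F)c3)cc2)C(=O)NC(C)C)c1` gives 932 nM in an assay on isolated protein with Bile acid receptor (Homo sapiens) as the target; on this read-out lower numbers stand for an effect already at smaller amounts and higher numbers for an effect only at larger amounts of compound. Within the data shown here, compound 2 `COC(=O)/C=C/c1cccc(N(Cc2ccc(-c3ccc(N(C)C)cc3)cc2)C(=O)NC(C)C)c1` gives 162 nM in this assay, the lowest of the two numbers, with a 5.8-fold lower number from compound 1 to compound 2 (0.76 log units; beyond the scatter) the only step known, a modest one that came from swapping the group on the aromatic carbon.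

Compound 3 `COC(=O)/C=C/c1cccc(N(Cc2ccc(/C=C/C(=O)OC(C)(C)C)cc2)C(=O)NC(C)C)c1` differs from compound 2 at the same position: 2-(tert-butoxycarbonyl)ethenyl in place of 4-(dimethylamino)phenyl on an aromatic carbon. Among the measured compounds shown here, no measured step covers a ring-to-chain exchange of this kind; the one step at hand, from compound 1 to compound 2, only shows that the group at this site shifts the number by a modest amount. Compound 3 is therefore expected to move back toward the number of compound 1, a step of a 3.7-fold higher number from compound 2 to compound 3 (0.57 log units; beyond the scatter) being estimated. Compound 3 is estimated at 600 nM, within 150 nM to 2500 nM.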

Compound 3, half-maximal effective concentration: 212 nM
The estimate for compound 3 lay 2.8-fold (0.45 log units) above the measured number, and the stated range covers the measured number.
By their numbers in this assay, from the lowest: compounds 2 and 3 (each within the scatter of the next); then compound 1.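

In this assay, an open 2-(tert-butoxycarbonyl)ethenyl chain with no ring and a 4-(dimethylamino)phenyl group on this aromatic carbon cannot be told apart, with a 1.3-fold higher number from compound 2 to compound 3 (0.12 log units; within the scatter), so an aromatic ring directly on this carbon is not required for a number in this range. With the ethenyl unit kept, tert-butoxycarbonyl in place of 3-(trifluoromethyl)phenyl gives a 4.4-fold lower number from compound 1 to compound 3 (0.64 log units; beyond the scatter), so the group at the end of the chain matters, not the ethenyl unit alone. Nothing at hand explains either step.

Open, as far as these compounds go, is whether a free carboxylic acid or an amide in place of the tert-butyl ester would keep the number. From the compounds shown here alone, the methyl ester and the isopropyl group are the same in all three compounds, so what they contribute also remains open.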